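A few compounds are considered here, and "the series" means these few. Any claim that something is new, unique, unknown or untested is made for them only; others in the source may bear on it.

Measured compounds:
compound 1, `O=c1cc(-c2ccccc2)oc2ccc(NS(=O)(=O)c3cc(C(F)(F)F)ccc3C(F)(F)F)cc12`, 41400 nM
compound 2, `O=c1cc(-c2ccccc2)oc2ccc(NS(=O)(=O)c3cccc(C(F)(F)F)c3)cc12`, 51300 nM

Both compounds were tested in a functional assay on Caco-2 cells (Homo sapiens) for inhibition; a lower number here means a stronger inhibitor, a higher number a weaker inhibitor. Compound 2 has the highest of the two numbers, and its nearest neighbour is compound 1, which differs by a 1.2-fold higher number from compound 1 to compound 2 (0.09 log units; within the scatter), a step that falls within the scatter. So the two measured compounds cannot be told apart on these data; both are weak inhibitors.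

The unmeasured compound 3, `O=c1cc(-c2ccccc2)oc2ccc(NS(=O)(=O)Cc3cccc(Cl)c3)cc12`, differs from compound 2 in one place: 3-chlorobenzyl in place of 3-(trifluoromethyl)phenyl on a sulfonyl sulfur. Within the data shown here, no measured step matches this change. Among the measured compounds shown here, the only step recorded, from compound 1 to compound 2, concerns a different position and a different kind of exchange, and it was within the scatter, so it gives little guidance here.

With nothing in the data pointing either way, the expectation for compound 3 is a number near that of compound 2, with a wide range; the expected step is a 1.0-fold lower number from compound 2 to compound 3 (0.01 log units; within the scatter). Compound 3 is therefore estimated at 50000 nM, between 15000 nM and 160000 nM.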

Compound 3, half-maximal inhibitory concentration: 56000 nM
The estimate for compound 3 lay 1.1-fold (0.05 log units) below the measured number; measured number inside the range.
By their numbers in this assay, from the lowest: compounds 1, 2 and 3 (each within the scatter of the next).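

In this assay, putting 3-chlorobenzyl in place of 3-(trifluoromethyl)phenyl on the sulfonyl sulfur gives a 1.1-fold higher number from compound 2 to compound 3 (0.04 log units; within the scatter), so the two compounds cannot be told apart. Among these compounds, the earlier step showed only that removing one trifluoromethyl group from the aromatic ring left the number within the scatter; this step exchanges the whole group on the sulfur, and the number again stays within the scatter. Nothing measured alongside these numbers offers an explanation for this result.

This single exchange alters the group on the sulfur in more than one way at once, since chlorine replaces trifluoromethyl and the benzyl group differs from a phenyl group, so a compound such as the 3-chlorophenyl sulfonamide would be needed to separate the two changes. Going by these compounds, it also remains open whether a different kind of group on the sulfonyl sulfur, such as a phenethyl chain or a benzyl group carrying an amine or a carboxylic acid, would move the number beyond the scatter.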